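The compounds below may be only part of what the source reports. "The series", "measured", "known", "first", "only" and "open" are said of these compounds alone.

Of the compounds shown here, two have been tested in an ADME assay on NIH3T3 cells (Mus musculus) for cytotoxicity, read by MTT assay, with a stated time of 24 h; a lower number here means a stronger inhibitor, a higher number a weaker inhibitor. Compound 1 `O=C(CN1CCN(c2cccc(Cl)c2)CC1)N1CCN(c2nnc(-c3ccccc3)c(-c3ccccc3)n2)CC1` gives 178000 nM in this assay. Compound 2 `O=C(CN1CCN(c2ccccc2)CC1)N1CCN(c2nnc(-c3ccc(Cl)cc3)c(-c3ccc(Cl)cc3)n2)CC1` reaches only the boundary of the assay, > 850000 nM, which is a limit rather than a measured number; this is the limit of > 850000 nM in this assay, at which 1 of the 2 values shown sits. Compound 2 therefore stands at the weak end of what the two results show, without a figure of its own.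

The next compound, compound 3 `O=C(CN1CCN(c2ccccc2Cl)CC1)N1CCN(c2nnc(-c3ccc(Cl)cc3)c(-c3ccc(Cl)cc3)n2)CC1`, differs from compound 2 in one place: chloro in place of hydrogen on an aromatic carbon. Within the data shown here, no step between two measured compounds carries this change, so there is no measured guide to its size. The expected step from compound 2 to compound 3 in this assay, an at least 1.0-fold lower number from compound 2 to compound 3 (0.02 log units; that floor lies within the scatter), is none beyond the scatter. Compound 3 is expected to give about 800000 nM, within 250000 nM to 2500000 nM, and most likely only a limit again.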

Compound 3, half-maximal inhibitory concentration: > 803000 nM
Compound 3: only a limit was reported; the forecaster's own chance of this, stated with the estimate: 70%; middle value at least 1.0-fold (0.00 log units) away from the limit.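

In this assay, among these compounds, compound 2 and compound 3 each give only a limit rather than a measured number, so no step between them can be read. Going by these compounds, whether the change from phenyl to 2-chlorophenyl shifts the result at all, and in which direction, stays open.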